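This account rests on a few compounds, and the source may have more. Where it says the series, first, only, none or still open, it means among the compounds named here.

Measured so far:
compound 1 `COc1cc(Cl)cc(-c2nn(-c3cccc(NC(=O)Nc4ccc(Cl)c(C(F)(F)F)c4)c3)cc2-c2ccncc2)c1` — 99%
compound 2 `COc1cc(Cl)cc(-c2nn(-c3cccc(NC(=O)Nc4cc(C(F)(F)F)cc(C(F)(F)F)c4)c3)cc2-c2ccncc2)c1` — 98%

Among the measured compounds shown here, in a functional assay on COLO 205 cells (Homo sapiens) for inhibition, read by sulforhodamine B assay, with a stated time of 48 h, tested at 0.1 uM (on this read-out lower numbers stand for a stronger effect and higher numbers for a weaker effect at the one concentration tested), compound 1 gives 99%; only two numbers exist, and compound 2 gives 98%, which lies within the scatter of compound 1, so no order can be set between them. Compound 3 `COc1cc(Cl)cc(-c2nn(-c3cccc(NC(=O)c4cccc(C(F)(F)F)c4)c3)cc2-c2ccncc2)c1` is not yet measured and differs from compound 1 by 3-(trifluoromethyl)phenyl in place of (4-chloro-3-(trifluoromethyl)phenyl)amino on a carbonyl carbon. For the measured compounds named here, no step between measured compounds covers this change. The step of a number 3 percentage points lower from compound 1 to compound 3 (within the scatter) is expected to be small, in either direction and not beyond the scatter. Compound 3 is therefore estimated at 96%, with a range from 82% to 106%.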

Compound 3, a percentage reported as activity, at one concentration (the size of the read-out at that concentration, not a potency): 101%
The estimate for compound 3 lay 5 percentage points below the measured number, and the stated range covers the measured number.
By their numbers in this assay, from the lowest: compounds 2, 1 and 3 (each within the scatter of the next).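

In this assay, exchanging the urea-type (4-chloro-3-(trifluoromethyl)phenyl)amino for 3-(trifluoromethyl)phenyl on the carbonyl carbon gives a number 2 percentage points higher from compound 1 to compound 3 (within the scatter). At this one concentration, the read-out therefore tolerates a change at this place that removes a nitrogen, its hydrogen-bond donor and the chlorine together, without a step beyond the scatter. No measured evidence bears on why the step is this small.

Still open, as far as these compounds go, is how the nitrogen and the chlorine would each act alone. Also open, from the compounds shown here alone, is whether a carboxylic acid or a morpholine on this carbonyl carbon would move the number beyond the scatter.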